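The compounds below may be only part of what the source reports. "The series", "measured", "known", "first", "only" and "open" are said of these compounds alone.

Compound 1 `CCCCCCCCCCc1ccc(-c2noc(CCCN)n2)cc1` — 67%
Compound 2 `CCCCCCCc1ccc(-c2noc(CCCN)n2)cc1` — 52%
Compound 3 `CCCCCCCCc1ccc(-c2noc(CCCN)n2)cc1` — 70%

Of the compounds shown here, three have so far been measured in an assay on HeLa cells for inhibition of sphingosine-1-phosphate transporter SPNS2 (Mus musculus), read by LC-MS, tested at 2 uM; a lower number here means less inhibition, a higher number more inhibition at the concentration tested (going by the name of the read-out); they share one core and differ only in the length of the chain on the aromatic ring. Compound 3 stands highest of the three numbers. The nearest value belongs to compound 1, and the step of a number 3 percentage points higher from compound 1 to compound 3 (within the scatter) lies within the scatter, so the two cannot be ordered. The gap to compound 2 is larger: a number 18 percentage points higher from compound 2 to compound 3 (beyond the scatter) is beyond the scatter, and a number 15 percentage points lower from compound 1 to compound 2 (beyond the scatter) points the same way, so the shortest chain gives the lowest number.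

Compound 4 `CCCCCCCCCc1ccc(-c2noc(CCCN)n2)cc1` has not yet been measured. It differs from compound 3 by methyl in place of hydrogen on a saturated chain carbon, eight bonds along the chain from an aromatic carbon. For the measured compounds named here, the steps that bear on this are the chain-lengthening ones: a number 18 percentage points higher from compound 2 to compound 3 (beyond the scatter) was modest, while a number 3 percentage points higher from compound 1 to compound 3 (within the scatter) showed that two further carbons change nothing beyond the scatter. Compound 4 sits between compound 3 and compound 1 in chain length, and those two values are within the scatter of each other, so no step beyond the scatter is expected: a number 2 percentage points lower from compound 3 to compound 4 (within the scatter). Compound 4 is therefore estimated at 68%, with a range from 56% to 80%.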

Compound 4, a percentage reported as inhibition, at one concentration (the size of the read-out at that concentration, not a potency): 61%
Estimate against measurement, compound 4: 7 percentage points above; low and high end bracket the measured number.
By their numbers in this assay, from the lowest: compounds 2, 4, 1 and 3 (each within the scatter of the next, the first and the last beyond it).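

In this assay, methyl in place of hydrogen on a saturated chain carbon, eight bonds along the chain from an aromatic carbon, gives a number 9 percentage points lower from compound 3 to compound 4 (within the scatter), so this change at this position has no effect that can be told from the scatter. For the compounds shown here, compound 4 also stays within the scatter of the other two compounds, with a number 9 percentage points higher from compound 2 to compound 4 (within the scatter) and a number 6 percentage points lower from compound 1 to compound 4 (within the scatter), making it the first compound that cannot be separated from any other, while compound 2 remains apart from compounds 1 and 3 only. The methyl step that cleared the scatter one position closer to the aromatic carbon therefore has no clear counterpart at the end of the series, although the two steps themselves cannot be told apart: the same change on two cores in this assay, a number 18 percentage points higher (beyond the scatter) from compound 2 to compound 3 and a number 6 percentage points higher (within the scatter) from compound 4 to compound 1, 12 percentage points apart, within the scatter of two such steps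

As far as these compounds go, the order of compounds 1, 3 and 4 remains open, as does whether a real difference would emerge with more repeats. The compounds shown also leave open how a longer chain, a shorter chain or an ether oxygen within the chain would read in this assay.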